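The compounds below may be only part of what the source reports. "The series", "measured", "known", "first", "only" and "open" are said of these compounds alone.

Measured in a functional assay (trachea) with Cavia porcellus as the target; on this read-out higher numbers stand for weaker inhibition and lower numbers for stronger inhibition:
- Compound 1 `Cn1nc(-c2cccnc2)c2ccccc2c1=O`: 11500 nM
- Compound 2 `CC(C)n1nc(-c2cccnc2)c2ccccc2c1=O`: 3090 nM
- Compound 3 `CCCCCCCCn1nc(-c2cccnc2)c2ccccc2c1=O`: 21900 nM

Compound 3 stands at 21900 nM. It cannot be separated from the methyl compound, given a 1.9-fold higher number from compound 1 to compound 3 (0.28 log units; within the scatter), but it is separated from the isopropyl compound by a 7.1-fold higher number from compound 2 to compound 3 (0.85 log units; beyond the scatter). The methyl compound itself differs from the isopropyl compound by a 3.7-fold lower number from compound 1 to compound 2 (0.57 log units; beyond the scatter).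

The next compound, compound 4 `O=c1c2ccccc2c(-c2cccnc2)nn1CC1CCCCC1`, arises through (cyclohexyl in place of heptyl on a saturated chain carbon bound to an aromatic nitrogen). Cut one bond further out, the same difference reads octyl to cyclohexylmethyl. For the measured compounds named here, no measured step makes this exact change, so the guide is indirect. Compound 2 shows, through a 7.1-fold higher number from compound 2 to compound 3 (0.85 log units; beyond the scatter), how far the number can shift when the octyl group is exchanged on the same core. Only part of that shift is expected here, and in the same direction, towards a lower number. The step expected in this assay is a 3.4-fold lower number from compound 3 to compound 4 (0.53 log units; beyond the scatter), a modest one whose uncertainty is wide. Compound 4 is estimated at 6500 nM, with an expected range of 2200 nM to 19000 nM.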

Compound 4, half-maximal inhibitory concentration: 209 nM
For compound 4 the middle estimate is 31-fold (1.49 log units) above the measured one, outside the stated range (below it).
By their numbers in this assay, from the lowest: compound 4; then compound 2; then compounds 1 and 3 (each within the scatter of the next).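

In this assay the open chain and the ring do not behave alike at this position: with cyclohexyl in place of heptyl on the saturated chain carbon bound to the aromatic nitrogen, the number falls sharply (a 100-fold lower number from compound 3 to compound 4 (2.02 log units; beyond the scatter)). The cyclohexylmethyl group also outdoes the two small groups, by a large step from the isopropyl compound (a 15-fold lower number from compound 2 to compound 4 (1.17 log units; beyond the scatter)) and a larger one from the methyl compound (a 55-fold lower number from compound 1 to compound 4 (1.74 log units; beyond the scatter)). Group size alone therefore does not order these compounds, since compound 3 and compound 4 both carry large groups yet lie at opposite ends of the series.

From the compounds shown here alone, it remains open whether the ring needs its connecting carbon, and whether a benzyl group or a piperidine ring, which carries an amine, would serve equally well. Nothing given here explains why the ring has this effect.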